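This account rests on a few compounds, and the source may have more. Where it says the series, first, only, none or still open, it means among the compounds named here.

Measured so far in an assay on lysate for inhibition of phosphatidylcholine:ceramide cholinephosphotransferase 2 (Homo sapiens), read by HPLC, with stated times of 30 min and 2 h; a higher number here means a weaker inhibitor, a lower number a stronger inhibitor:
compound 1, `O=C(Nc1cccnc1)c1ccccc1OCc1ccccc1`, gives 3200 nM;
compound 2, `O=C(Nc1cccnc1)c1ccccc1OCc1ccccc1Cl`, gives 1100 nM.

In this assay, among the measured compounds shown here, compound 2 stands at the lowest of the two numbers, with compound 1 as its only neighbour. For the measured compounds named here, the single measured step, a 2.9-fold lower number from compound 1 to compound 2 (0.46 log units; beyond the scatter), is beyond the scatter and is the only guide the set offers.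

Compound 3, `O=C(Nc1cccnc1)c1ccccc1OCc1ccccc1C(F)(F)F`, differs from compound 2 in one place: trifluoromethyl in place of chloro on an aromatic carbon. Going by the values given here, no measured pair exchanges chloro for trifluoromethyl, so the step from compound 1 to compound 2 bears on it only indirectly: it shows that a substituent at this carbon lowered the number in this assay, but not whether a second exchange at the same carbon moves further. In this assay a step from compound 2 to compound 3 is expected to be no larger than the measured one and may stay within the scatter. Compound 3 is therefore estimated at 800 nM, with a range from 300 nM to 2500 nM. This estimate amounts to an expected 1.4-fold lower number from compound 2 to compound 3 (0.14 log units; within the scatter).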

Compound 3, half-maximal inhibitory concentration: 2100 nM
Beside the measured number, compound 3's estimate is 2.6-fold (0.42 log units) below it; measured number inside the range.
By their numbers in this assay, from the lowest: compounds 2, 3 and 1 (each within the scatter of the next, the first and the last beyond it).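

In this assay, trifluoromethyl in place of chloro on this aromatic carbon gives a 1.9-fold higher number from compound 2 to compound 3 (0.28 log units; within the scatter) and so does not separate the two groups. Trifluoromethyl in place of hydrogen gives a 1.5-fold lower number from compound 1 to compound 3 (0.18 log units; within the scatter), which leaves compound 3 unresolved from compound 1 as well, whereas chloro in place of hydrogen gave a step beyond the scatter (a 2.9-fold lower number from compound 1 to compound 2 (0.46 log units; beyond the scatter)), so the three compounds do not show a clear benefit from substitution here beyond that one chloro step. No available evidence bears on the reason for these steps.

On these data alone, whether the lower number of compound 2 is particular to chloro or extends to other small groups remains open. A methyl, methoxy, fluoro or nitrile group on this carbon, or an amine or carboxylic acid in the same place, could test that.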